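Ring swap from compound 3 to compound 4

This account rests on a few compounds, and the source may have more. Where it says the series, first, only, none or still open, it means among the compounds named here.

compound 1 `CCCCNC(=O)C(=O)NCCCC/C=C\CCCCCCC(=O)OCCOCCOCCO` gives 1500 nM
compound 2 `CCCCCNC(=O)NCCCC/C=C\CCCCCS(=O)(=O)c1ncn[nH]1` gives 3100 nM
compound 3 `CCCCCNC(=O)NCCCC/C=C\CCCCCCCc1nnn[nH]1` gives 1100 nM

In a functional assay on Coronary artery (Bos taurus) (a higher number here means that more compound is needed for the effect, a lower number that less compound is needed), compound 3 at 1100 nM stands within the scatter of compound 1 and clearly under compound 2. Compound 4 `CCCCCNC(=O)NCCCC/C=C\CCCCCCc1nsc(=O)[nH]1` is still unmeasured and carries a group of 6 heavy atoms (2 carbon, 2 nitrogen, 1 oxygen, 1 sulfur; one five-membered aromatic ring with 3 hetero atoms) in place of a group of 6 heavy atoms (2 carbon, 4 nitrogen; one five-membered aromatic ring with 4 hetero atoms), on a saturated chain carbon, six bonds along the chain from a double-bonded chain carbon as its change. Going by the values given here, the only measured step that bears on this is a 2.8-fold lower number from compound 2 to compound 3 (0.45 log units; beyond the scatter) and it is modest. Among the compounds with values here, that step also exchanges one five-membered aromatic ring for another, but the ring entering compound 4 has no measured precedent here. A small move that stays within the scatter is therefore expected, leaning slightly to a higher number. The estimated step is a 1.4-fold higher number from compound 3 to compound 4 (0.13 log units; within the scatter) in this assay on this limited evidence. Compound 4 is expected at 1500 nM with an estimated range from 500 nM to 4500 nM in this series.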

Compound 4, half-maximal effective concentration: 2400 nM
Compound 4: middle estimate off by 1.6-fold (0.20 log units), on the low side; low and high end bracket the measured number.
By their numbers in this assay, from the lowest: compounds 3, 1, 4 and 2 (each within the scatter of the next, the first and the last beyond it).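

In this assay, this position responds to a ring swap at an unchanged heavy-atom count: a 2.2-fold higher number from compound 3 to compound 4 (0.34 log units; beyond the scatter). Going by these compounds alone, the second new step, a 1.3-fold lower number from compound 2 to compound 4 (0.11 log units; within the scatter), stays within the scatter, so among the three ring-bearing compounds only the one carrying (1H-tetrazol-5-yl)methyl stands clearly apart from the sulfonyl-linked ring. Nothing available explains the size of either step.

Still open, going by these compounds, is whether a carboxylic acid on this chain carbon would stay level with the tetrazole. A longer chain carrying the ring of compound 4 is also untested among the compounds shown.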